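Trifluoromethyl for iodo: compound 1 to compound 4

The source may report more compounds than this note shows. Statements on the series, on what has been measured and on what is new or still open speak of the compounds shown alone.

Three members of the series carry readings in a functional assay on MCF7 cells (Homo sapiens) for inhibition, read by sulforhodamine B assay; a higher number here means a weaker inhibitor, a lower number a stronger inhibitor. Compound 1 `O=C1C=C(Nc2ccc(I)cc2)C(=O)c2c1nc1n2[C@H]2OC[C@@H](O)[C@H]2OC1` gives 2230 nM in this assay, the lowest of the two numbers shown. Compound 2 `Cc1ccc(NC2=CC(=O)c3c(nc4n3[C@H]3OC[C@@H](O)[C@H]3OC4)C2=O)cc1C` gives 4950 nM, a higher number than compound 1 by a margin beyond the usual scatter. Compound 3 `CCOc1ccc(NC2=CC(=O)c3c(nc4n3[C@H]3OC[C@@H](O)[C@H]3OC4)C2=O)cc1` reaches only a limit of the assay, > 4000 nM. For the measured compounds named here, the single one-place step among the measured compounds, a step that the limit leaves unreadable from compound 2 to compound 3, cannot be sized because its end point sits at the limit of > 4000 nM in this assay, at which 1 of the 3 values shown sits.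

Compound 4 `O=C1C=C(Nc2ccc(C(F)(F)F)cc2)C(=O)c2c1nc1n2[C@H]2OC[C@@H](O)[C@H]2OC1` differs from compound 1 in one place: trifluoromethyl in place of iodo on an aromatic carbon. Going by the values given here, no measured pair shares this change; the only measured step concerns other groups on the amine nitrogen and yields no readable size, so nothing sets the direction. What is counted for the change is small: both groups are uncharged, carry no hydrogen-bond donors or acceptors and add no ring. The expectation in this assay is therefore a step of a 1.3-fold higher number from compound 1 to compound 4 (0.10 log units; within the scatter), nothing beyond the scatter in either direction. Compound 4 is estimated at 2800 nM, within a range of 1100 nM to 7500 nM, with a fair chance that the reading comes back only as a limit.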

Compound 4, half-maximal inhibitory concentration: > 4000 nM
Compound 4 was reported as a limit; the forecaster's own chance of this, stated with the estimate: 30%; at least 1.4-fold (0.15 log units) between middle value and limit.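

In this assay, replacing 4-iodophenyl with 4-(trifluoromethyl)phenyl reads as an at least 1.7-fold higher number from compound 1 to compound 4 (0.25 log units; that floor lies within the scatter), which gives the series its first one-place step with a readable floor; the earlier step on the amine nitrogen gave none. This floor says only that the true size of the step cannot be smaller, so the change on this aromatic carbon is not yet placed beyond the scatter, while any larger size remains possible. Compound 4 is reported only as a limit, which adds a second compound at the same ceiling of the assay and narrows what the series can rank: the limit of > 4000 nM in this assay, at which 2 of the 4 values shown sit.

From the compounds shown here alone, how far compound 4 lies past its limit remains open, and so does whether the step from iodo is specific to trifluoromethyl. The compounds shown also leave open what a bromo, a chloro, a nitrile or a carboxylic acid on the same aromatic carbon would read, and any of these could show whether this position supports values within the readable range of the assay.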